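Swapping the benzyl substituent on an HDAC6 hydroxamate

The source may hold more compounds than are shown below. What is called first, only, known or untested is meant among the compounds shown, and "the series" means these compounds.

Compound 3 `CN(Cc1nc(C2CCN(Cc3ccc(C(F)(F)F)cc3)CC2)no1)c1ncc(C(=O)NO)cn1` gives 30% in an assay on isolated protein for inhibition of protein deacetylase HDAC6 (Homo sapiens), read by fluorescence, with a stated time of 1 h, tested at 100 nM; a lower number here means less inhibition, a higher number more inhibition at the concentration tested (going by the name of the read-out). Among the three measured compounds it sits at the low end: a number 8 percentage points lower from compound 2 to compound 3 (within the scatter), so compound 2 `CN(Cc1nc(C2CCN(Cc3ccc(C#N)cc3)CC2)no1)c1ncc(C(=O)NO)cn1` with 38% is not separable from it, while a number 33 percentage points lower from compound 1 to compound 3 (beyond the scatter) sets it clearly apart from compound 1 `CN(Cc1nc(C2CCN(Cc3ccccc3)CC2)no1)c1ncc(C(=O)NO)cn1` with 63%. Compound 4 `CN(Cc1nc(C2CCN(Cc3ccc(F)cc3Cl)CC2)no1)c1ncc(C(=O)NO)cn1` is unmeasured; it differs from compound 3 in one place: 2-chloro-4-fluorophenyl in place of 4-(trifluoromethyl)phenyl on a saturated chain carbon bound to an amine nitrogen in a ring. The relevant steps all replace hydrogen on that ring with a group: a number 25 percentage points lower from compound 1 to compound 2 (beyond the scatter) and a number 33 percentage points lower from compound 1 to compound 3 (beyond the scatter), and the exchange of one such group for another, a number 8 percentage points lower from compound 2 to compound 3 (within the scatter). Compound 4 keeps a substituted ring, so for it a step of roughly a number 10 percentage points higher from compound 3 to compound 4 (within the scatter) is expected, small in either direction. Compound 4 is estimated at 40%, between 22% and 58%.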

Compound 4, a percentage reported as inhibition, at one concentration (the size of the read-out at that concentration, not a potency): 49%
Estimate against measurement, compound 4: 9 percentage points below; measured number inside the range.
By their numbers in this assay, from the lowest: compounds 3 and 2 (each within the scatter of the next); then compound 4; then compound 1.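

Groups on this benzyl ring can now be told apart: in this assay there is a number 19 percentage points higher from compound 3 to compound 4 (beyond the scatter) and a number 11 percentage points higher from compound 2 to compound 4 (beyond the scatter) with 2-chloro-4-fluorophenyl, whereas 4-cyanophenyl and 4-(trifluoromethyl)phenyl could not be separated. Even so, the plain phenyl stays ahead, with a number 14 percentage points lower from compound 1 to compound 4 (beyond the scatter) and so every substituted ring shown gives a lower number than it. Nothing measured here explains these differences.

Going by these compounds, whether the chlorine or the fluorine carries the step remains open. So does what an amine or a carboxylic acid on this ring would do.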